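Second chloro on the aryl amino group: compound 3

This account rests on a few compounds, and the source may have more. Where it says the series, first, only, none or still open, it means among the compounds named here.

Series values so far in a functional assay on KB cells (Homo sapiens) for cytotoxicity (a lower number here means a stronger inhibitor, a higher number a weaker inhibitor), for two compounds:
- compound 1 `Cc1c(S(=O)(=O)N/C(=N\O)Nc2ccc(Cl)cc2)sc2ccc(Cl)cc12` gives 29 ug/mL
- compound 2 `O=[N+]([O-])c1ccc(Oc2c(Cl)cc(S(=O)(=O)N/C(=N\O)Nc3ccc(Cl)cc3)cc2Cl)cc1` gives 12 ug/mL

Compound 1 holds the higher of the two numbers, and compound 2 sits lower by more than the scatter. These two compounds differ in more than one place, so their gap isolates no single change.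

Compound 3 `Cc1c(S(=O)(=O)N/C(=N\O)Nc2ccc(Cl)c(Cl)c2)sc2ccc(Cl)cc12` is still unmeasured. It departs from compound 1 by going from 4-chlorophenyl to 3,4-dichlorophenyl: chloro in place of hydrogen on an aromatic carbon, ortho to a chloro group and meta to a large group (chloro in place of hydrogen on an aromatic carbon). Among the compounds with values here, no measured pair shows this change, so the expectation is loose. In this assay no step beyond the scatter is expected, with a slight lean toward a lower number. The estimated size is a 1.5-fold lower number from compound 1 to compound 3 (0.16 log units; within the scatter) and remains only an expectation. The estimated value for compound 3 is 20 ug/mL (expected range 9 ug/mL to 40 ug/mL).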

Compound 3, half-maximal inhibitory concentration: > 300 ug/mL
Compound 3 ended at the assay's limit; the forecaster's own chance of this, stated with the estimate: 5%; middle value at least 15-fold (1.17 log units) from the limit.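

In this assay, going from 4-chlorophenyl to 3,4-dichlorophenyl gives an at least 10-fold higher number from compound 1 to compound 3 (1.01 log units; beyond the scatter). Compound 1 and compound 2 both carry the 4-chlorophenyl group, so neither could show that this aromatic ring responds so sharply: chloro in place of a hydrogen, a single heavy atom, is enough to move the read-out to the end of its range. The value of compound 3 is a limit of the assay, not a number: the limit of > 300 ug/mL in this assay, at which 1 of the 3 values shown sits.

Open, on these data alone, is whether a fluoro, a methyl or a methoxy group at this place would give the same shift in the read-out as chloro. Also open, as far as these compounds go, is whether the same chloro in place of hydrogen, on the core of compound 2, would move the number in the same direction and by a similar size.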